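The compounds below may be only part of what the source reports. "The series", "measured", "known", "first", "only" and "open" are said of these compounds alone.

Of the compounds shown here, three have already been measured in a functional assay on UO-31 cells (Homo sapiens) for antiproliferative activity, read by sulforhodamine B assay, with a stated time of 72 h; on this read-out lower numbers stand for stronger inhibition and higher numbers for weaker inhibition. Compound 1 `Cc1ccc(C(/C=C/c2ccc(F)cc2)=N\Nc2nncc3ccccc23)cc1` gives 5.3 nM in this assay, and compound 2 `Clc1ccc(C(/C=C/c2ccccc2)=N\Nc2nncc3ccccc23)cc1` gives 6.2 nM. Compound 3 `O=S(=O)(Nc1ccccn1)c1ccc(Nc2nncc3ccccc23)cc1` is built on a different pattern from the first two, and in this assay compound 3 gives 44 nM. That is the highest of the three numbers: the nearest of the other two is compound 2, the furthest is compound 1, and both gaps lie beyond the scatter, so compound 3 is the weakest of the measured set.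

Compound 4 `O=S(=O)(Nc1ncccn1)c1ccc(Nc2nncc3ccccc23)cc1` has not yet been measured. It differs from compound 3 in one place: pyrimidin-2-yl in place of pyridin-2-yl on a sulfonamide nitrogen. For the measured compounds named here, no measured pair isolates this exchange, so the expectation rests on compound 3 alone and on the fact that one six-membered aromatic ring is exchanged for another. The step from compound 3 to compound 4 is expected to be a 1.1-fold higher number from compound 3 to compound 4 (0.06 log units; within the scatter), a step not beyond the scatter in either direction. Compound 4 is therefore estimated at 50 nM, with a range of 20 nM to 130 nM.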

Compound 4, half-maximal inhibitory concentration: 23 nM
Estimate against measurement, compound 4: 2.2-fold (0.34 log units) above; the range from low to high includes it.
By their numbers in this assay, from the lowest: compounds 1 and 2 (each within the scatter of the next); then compounds 4 and 3 (each within the scatter of the next).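

In this assay, putting pyrimidin-2-yl in place of pyridin-2-yl on a sulfonamide nitrogen gives a 1.9-fold lower number from compound 3 to compound 4 (0.28 log units; within the scatter), so at this position a six-membered aromatic ring with 2 hetero atoms cannot be told apart from one with 1 hetero atom. For the compounds shown here, this is the first pair here that differs in only one place, which makes it the first direct reading of this position; compound 3 on its own could not show how the position responds to a change. No measurement of any property of these two rings is available to bear on this result.

As far as these compounds go, it remains open how the position responds to a methyl group, a thiazol-2-yl ring or a longer alkyl chain on the sulfonamide nitrogen. It is also unknown whether the same ring exchange would give a similar step on another core.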